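The source may hold more compounds than are shown below. What is called first, only, known or untested is meant among the compounds shown, and "the series" means these compounds.

Compound 1 `CN(C)c1ncnc2c1c(-c1ccsc1)cn2[C@@H]1O[C@H](CO)[C@@H](O)[C@H]1O`: in a functional assay on HL-60 cells (Homo sapiens) for antiproliferative activity, read by XTT assay, with a stated time of 72 h (a higher number here means a weaker inhibitor, a lower number a stronger inhibitor), compound 1 gives 1920 nM
Compound 2 `C#Cc1cn([C@@H]2O[C@H](CO)[C@@H](O)[C@H]2O)c2ncnc(N(C)C)c12`: in this assay compound 2 gives 290 nM
Compound 3 `CN(C)c1ncnc2c1c(-c1cc3ccccc3o1)cn2[C@@H]1O[C@H](CO)[C@@H](O)[C@H]1O`: in this assay compound 3 gives only a limit, > 20000 nM

Among the two numbers in hand, compound 1 is the higher one; its nearest neighbour is compound 2, reached by a 6.6-fold lower number from compound 1 to compound 2 (0.82 log units; beyond the scatter). Compound 3 sits at a limit of this assay and yields no number (the limit of > 20000 nM in this assay, at which 1 of the 3 values shown sits). Accordingly, in this assay compound 3 stands beyond compound 1 by an at least 10-fold higher number from compound 1 to compound 3 (1.01 log units; beyond the scatter) and beyond compound 2 by an at least 68-fold higher number from compound 2 to compound 3 (1.83 log units; beyond the scatter), both reported as limits.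

Compound 4 `CSc1ncnc2c1c(-c1ccsc1)cn2[C@@H]1O[C@H](CO)[C@@H](O)[C@H]1O` is the next member to be measured. It differs from compound 1 as follows: methylsulfanyl in place of dimethylamino on an aromatic carbon.

All three measured steps exchange the thiophen-3-yl, ethynyl or 1-benzofuran-2-yl group on the shared core; none of them touches the dimethylamino group. For the measured compounds named here, no measured step therefore bears directly on the change to compound 4. With no evidence in either direction, the expectation for compound 4 in this assay is a step of a 1.0-fold lower number from compound 1 to compound 4 (0.00 log units; within the scatter), within the scatter, with broad uncertainty on both sides. Compound 4 is estimated at 1900 nM, in the range 450 nM to 8000 nM.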

Compound 4, half-maximal inhibitory concentration: 4590 nM
The estimate for compound 4 lay 2.4-fold (0.38 log units) below the measured number, and the stated range covers the measured number.
By their numbers in this assay, from the lowest: compound 2; then compound 1; then compound 4. At a limit, above all of these: compound 3.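

For the compounds shown here, the earlier compounds vary only the thiophen-3-yl, ethynyl or 1-benzofuran-2-yl group, so this is the first reading at the aromatic carbon next to the ring nitrogen: in this assay, methylsulfanyl in place of dimethylamino gives a 2.4-fold higher number from compound 1 to compound 4 (0.38 log units; beyond the scatter). This carbon is therefore sensitive to the group it carries, yet dimethylamino is not needed for a measurable result, since with thiophen-3-yl held in place compound 4 still gives 4590 nM in this assay. Nothing measured here accounts for the size or direction of this step.

Open, going by these compounds, is whether a primary amine, a methoxy group or a longer alkylsulfanyl chain at this carbon would fall on the lower or the higher side of compound 1, which would help separate the effect of the entering sulfur from that of the departing nitrogen. Also open, on these data alone, is whether the same exchange carries a similar step on the ethynyl member, compound 2 at 290 nM, or whether it holds only alongside thiophen-3-yl.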